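A Second Chloro Group Added to Compound 3

A few compounds are considered here, and "the series" means these few. Any claim that something is new, unique, unknown or untested is made for them only; others in the source may bear on it.

Compound 3 `C[C@@H](NC(=O)Nc1ccccc1Cl)c1ccccc1` gives 93% in an ADME assay on the whole organism with Oryza sativa as the target, tested at 10 uM; a lower number here means a stronger effect, a higher number a weaker effect of the compound at the concentration tested. That places it second highest among the three measured numbers. Its nearest neighbour is compound 2 `COc1ccccc1NC(=O)N[C@H](C)c1ccccc1`, which in this assay gives 96%; the step of a number 3 percentage points lower from compound 2 to compound 3 (within the scatter) lies within the scatter. The furthest is compound 1 `C[C@@H](NC(=O)Nc1ccccc1C(F)(F)F)c1ccccc1`, which in this assay gives 54%; the step of a number 39 percentage points higher from compound 1 to compound 3 (beyond the scatter) lies beyond the scatter.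

Compound 4 `C[C@@H](NC(=O)Nc1ccc(Cl)cc1Cl)c1ccccc1` has not yet been measured. It differs from compound 3 in one place: chloro in place of hydrogen on an aromatic carbon.

The three measured steps all exchange one group for another at the same carbon: a number 42 percentage points higher from compound 1 to compound 2 (beyond the scatter) and a number 39 percentage points higher from compound 1 to compound 3 (beyond the scatter) are large, while a number 3 percentage points lower from compound 2 to compound 3 (within the scatter) is within the scatter. Within the data shown here, none of them adds a second group to a ring that already carries one, so no measured step bears directly on the change to compound 4. Among the measured compounds shown here, the only guidance is that chloro and methoxy give numbers close to each other and well above trifluoromethyl. For the measured compounds named here, with no direct precedent, the step of a number 8 percentage points lower from compound 3 to compound 4 (within the scatter) is expected to be small. Compound 4 is therefore estimated at 85%, with a range from 55% to 100%.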

Compound 4, a percentage reported as activity, at one concentration (the size of the read-out at that concentration, not a potency): 100%
Beside the measured number, compound 4's estimate is 15 percentage points below it, and the stated range covers the measured number.
By their numbers in this assay, from the lowest: compound 1; then compounds 3, 2 and 4 (each within the scatter of the next).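

Among these compounds, the step of a number 7 percentage points higher from compound 3 to compound 4 (within the scatter) in this assay is the first to add a second group to a ring that already carries one, and it shows that a chloro group can enter on this aromatic carbon, meta to a chloro group and para to a large group, with a step that stays within the scatter. The large steps seen earlier, such as a number 39 percentage points higher from compound 1 to compound 3 (beyond the scatter), came from exchanging the group on the carbon that carries the first chloro group, so they say nothing about this second place on the ring, whereas this step now gives a first reading there. The compounds shown offer no measurement that bears on the reason for this result.

The compounds shown leave open whether this place would respond in the same way to a different group, such as trifluoromethyl, methoxy, an amine or a carboxylic acid. They also leave open whether the same added chloro group would give a similarly small step on the trifluoromethyl compound, compound 1, which gives 54%.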